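A few compounds are considered here, and "the series" means these few. Any claim that something is new, unique, unknown or untested is made for them only; others in the source may bear on it.

Two compounds of the series have numbers in a functional assay on MCF7 cells (Homo sapiens) for antiproliferative activity; on this read-out higher numbers stand for weaker inhibition and lower numbers for stronger inhibition. Compound 1 `CCCCn1c(Cc2c(Br)c(OC)c(OC)c(OC)c2Br)nc2c(N)ncnc21` gives 30200 nM in this assay. Compound 2 `COc1cc(Cc2nc3c(N)ncnc3n2CC2CCCCC2)cc(OC)c1OC` gives 39800 nM in this assay; this is the higher of the two numbers, but the gap to compound 1 lies within the scatter, so the two compounds read the same on this assay. Going by the values given here, neither pair of measured compounds differs in a single place, so no isolated step is on record.

Compound 3 `C#CCCCn1c(Cc2cc(OC)c(OC)c(OC)c2)nc2c(N)ncnc21` has not been measured in this assay. Against compound 2 it differs in one place: but-3-yn-1-yl in place of cyclohexyl on a saturated chain carbon bound to an aromatic nitrogen. Among the compounds with values here, nothing measured so far separates the effect of the group on that carbon from the rest of the molecule, and both measured compounds sit close together, so the change is expected to give a step of no settled direction and of a size not beyond the scatter. The step expected from compound 2 to compound 3 is a 1.1-fold lower number from compound 2 to compound 3 (0.06 log units; within the scatter). In this assay compound 3 is estimated at 35000 nM, with an expected range from 12000 nM to 100000 nM.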

Compound 3, half-maximal inhibitory concentration: 24000 nM
For compound 3 the middle estimate is 1.5-fold (0.16 log units) above the measured one; low and high end bracket the measured number.
By their numbers in this assay, from the lowest: compounds 3, 1 and 2 (each within the scatter of the next).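

Going by these compounds alone, the first isolated step at this position, read in this assay, is a 1.7-fold lower number from compound 2 to compound 3 (0.22 log units; within the scatter), for but-3-yn-1-yl in place of cyclohexyl on a saturated chain carbon bound to an aromatic nitrogen. The two compounds therefore read the same: at this place, an open chain of 4 heavy atoms with a triple bond stands in for a six-membered non-aromatic carbon ring with no change beyond the scatter, which the earlier pair, differing in more than one place, could not show. No measured property of these groups is on hand to account for this reading.

On these data alone, both groups carry no hydrogen-bond donors or acceptors and no net charge, so it remains open whether an amine or a carboxylic acid on the same chain carbon, or a longer chain there, would move the number beyond the scatter. As far as these compounds go, it also remains open whether the same exchange would read alike on a compound carrying the two bromine atoms of compound 1.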